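The source may report more compounds than this note shows. Statements on the series, on what has been measured and on what is new or still open speak of the compounds shown alone.

Measured compounds:
- compound 1 `CC1(C)CC(=O)c2s/c(=N/c3ccc(Cl)cc3)oc2C1`: 6380 nM
- compound 2 `CC1CC(=O)c2s/c(=N/c3ccc(Cl)cc3)oc2C1`: 14300 nM
- compound 3 `CC1(C)CC(=O)c2s/c(=N/c3c(Cl)cc(Cl)cc3Cl)oc2C1`: > 30000 nM

Compound 1 and compound 2 differ by hydrogen in place of methyl on a saturated ring carbon. In a functional assay on MDA-MB-231 cells (Homo sapiens) for antiproliferative activity, read by sulforhodamine B assay (on this read-out higher numbers stand for weaker inhibition of growth and lower numbers for stronger inhibition of growth), this change gives a 2.2-fold higher number from compound 1 to compound 2 (0.35 log units; beyond the scatter). Compound 3 carries a different core; the difference between the two cores is not broken down here. For compound 3 this assay reports only a limit, namely > 30000 nM, and this is one of the values sitting at the limit of > 30000 nM in this assay, at which 1 of the 3 values shown sits.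

Compound 4 `CC1CC(=O)c2s/c(=N/c3c(Cl)cc(Cl)cc3Cl)oc2C1` is not yet measured. It is related to compound 3 by hydrogen in place of methyl on a saturated ring carbon, the same change that separates compound 1 from compound 2. Given that the step in this assay was a 2.2-fold higher number from compound 1 to compound 2 (0.35 log units; beyond the scatter), and that compound 3 already sits at the limit, compound 4 is expected to remain at or beyond that limit, an expected step that the limit leaves unreadable from compound 3 to compound 4. For compound 4 the estimated value is 60000 nM, expected between 30000 nM and 150000 nM.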

Compound 4, concentration for 50% growth inhibition: > 30000 nM
Compound 4: no number, only a limit; the forecaster's own chance of this, stated with the estimate: 85%; the middle value does not contradict the limit.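

Compound 3 and compound 4 both sit at a limit in this assay, so no step between them can be read: the limit of > 30000 nM in this assay, at which 2 of the 4 values shown sit.

The compounds shown leave open whether hydrogen in place of methyl on a saturated ring carbon acts on compound 3 as it does on compound 1.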